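The compounds below may be only part of what the source reports. "The series", "measured", "known", "first", "only" and "open" are said of these compounds alone.

Working notes on the series.

Compound 1 `Cc1cc(C)c(NC(=O)N(Cc2ccc(-c3n[nH]c(C)n3)cc2)C2CCCCCC2)c(C)c1` carries the cycloheptyl urea core with a 5-methyl-1H-1,2,4-triazol-3-yl on the benzyl arm. In a functional assay on a cell-free system (plasma) with sterol O-acyltransferase, Soat (Rattus norvegicus) as the target (a higher number here means that more compound is needed for the effect, a lower number that less compound is needed), compound 1 gives only a limit, > 1 mg/kg, and no number; this is where it stands, at the limit of > 1 mg/kg in this assay, at which 1 of the 3 values shown sits. Compound 2 `CSc1cc(C)nc(SC)c1NC(=O)N(Cc1ccccc1)Cc1cccc(-c2cc[nH]n2)c1` belongs to a different core and in this assay gives 0.046 mg/kg. Compound 3 `COc1ccc(CN(Cc2cccc(-c3cc[nH]n3)c2)C(=O)Nc2c(SC)cc(C)nc2SC)cc1` is the same core with a methoxy added; for compound 3 the result in this assay is a limit, < 0.1 mg/kg, which sits at the limit of < 0.1 mg/kg in this assay, at which 1 of the 3 values shown sits. Going by the values given here, the one measured step, a step that the limit leaves unreadable from compound 2 to compound 3, is therefore unreadable in size and concerns a change unrelated to the one followed here.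

Compound 4 `Cc1cc(C)c(NC(=O)N(Cc2ccc(-c3cnn(C)c3)cc2)C2CCCCCC2)c(C)c1` differs from compound 1 by 1-methyl-1H-pyrazol-4-yl in place of 5-methyl-1H-1,2,4-triazol-3-yl on an aromatic carbon. Among the compounds with values here, no measured step touches this exchange, and compound 1 itself is a limit, so the expectation rests on compound 1 alone. The expected step is a step that the limit leaves unreadable from compound 1 to compound 4, that is, no step beyond the scatter is expected. For compound 4 the estimate in this assay is 1.5 mg/kg, with a range from 0.3 mg/kg to 6 mg/kg, and a limit rather than a number is the more likely outcome.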

Compound 4, dose for half-maximal effect: 0.31 mg/kg
For compound 4 the middle estimate is 4.8-fold (0.68 log units) above the measured one; the range from low to high includes it.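

Going by these compounds alone, on the aromatic carbon para to a large group, in this assay the exchange of 5-methyl-1H-1,2,4-triazol-3-yl for 1-methyl-1H-pyrazol-4-yl gives an at least 3.2-fold lower number from compound 1 to compound 4 (0.50 log units; beyond the scatter) as the only readable step at this place. On these data alone, compound 1 gives > 1 mg/kg as a limit and not a number, so this step is a minimum and its full size stays open. The exchange removes the hydrogen-bond donor of the leaving group and one ring nitrogen, but nothing at hand assigns the step to either difference or gives it a cause.

The step between compound 2 and compound 3 cannot be read and concerns another core. Open at this place is how a pyrazole without the methyl, which would separate the donor from the ring nitrogen count, or a carboxylic acid would compare.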